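The source may report more compounds than this note shows. Statements on the series, on what has been measured and on what is new or still open speak of the compounds shown alone.

The measured compounds:
compound 1 `CCc1cccc2c(OC)c(-c3occ(C)c3C(=O)OC)ccc12`: in a functional assay on DU-145 cells (Homo sapiens) for cytotoxicity, read by MTT assay, with a stated time of 72 h (on this read-out higher numbers stand for an effect only at larger amounts of compound and lower numbers for an effect already at smaller amounts), compound 1 gives 2.2 ug/mL.
compound 2 `CCc1cccc2c(OC)c(-c3occ(C)c3CO)ccc12`: in this assay compound 2 gives 7.2 ug/mL.
compound 3 `CCOc1c(-c2occ(C)c2CO)ccc2c(CC)cccc12`: in this assay compound 3 reports only a limit, > 10 ug/mL.

Compound 2 holds the higher of the two numbers shown; the step between them is a 3.3-fold higher number from compound 1 to compound 2 (0.51 log units; beyond the scatter). The third value is a limit, at the limit of > 10 ug/mL in this assay, at which 1 of the 3 values shown sits, and the step onto it is an at least 1.3-fold higher number from compound 2 to compound 3 (0.14 log units; that floor lies within the scatter).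

Compound 4 `CCc1cccc2c(OC)c(-c3occ(C)c3COCC(F)(F)F)ccc12` differs from compound 2 by 2,2,2-trifluoroethyl in place of hydrogen on an oxygen on a saturated carbon. Within the data shown here, two measured steps bear on this change, each only in part: the one that replaced the methoxycarbonyl by the hydroxymethyl, which reached compound 2, and the one that extended the other oxygen by a methyl, which ended in a limit. The first was modest and beyond the scatter; the second has a floor within the scatter. Neither caps the hydroxymethyl oxygen itself, so the direction for compound 4 is open. Compound 4 is expected to give 6 ug/mL, within 2.5 ug/mL to 14 ug/mL, a step of a 1.2-fold lower number from compound 2 to compound 4 (0.08 log units; within the scatter) that is estimated to stay close to the scatter.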

Compound 4, concentration for half-maximal effect: 5.7 ug/mL
Compound 4: the middle estimate sits 1.1-fold (0.02 log units) above what was measured; the range from low to high includes it.
By their numbers in this assay, from the lowest: compound 1; then compounds 4 and 2 (each within the scatter of the next). At a limit, above all of these: compound 3.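

Among these compounds, on the hydroxymethyl oxygen, which no earlier step had touched, 2,2,2-trifluoroethyl in place of hydrogen gives a 1.3-fold lower number from compound 2 to compound 4 (0.10 log units; within the scatter), so in this assay this position carries the added group with no change that can be read. The methoxycarbonyl still stands apart from both groups that have replaced it, since exchanging it for (2,2,2-trifluoroethoxy)methyl gives a 2.6-fold higher number from compound 1 to compound 4 (0.41 log units; beyond the scatter), on the same side as the earlier exchange for hydroxymethyl. The data shown offer no explanation for either of these steps.

Whether the fluorine atoms matter at all stays open, since a plain ethyl or methyl on this oxygen does not appear among the compounds shown. So does the reach of this tolerance: a longer chain on the oxygen, or an amine in its place, could behave differently.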